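Dimethoxy substitution on the sulfonyl aryl of compound 3

The compounds below may be only part of what the source reports. "The series", "measured", "known", "first", "only" and "open" are said of these compounds alone.

Compound 3 `CN(c1ccc2[nH]c(-c3n[nH]c4ccccc34)cc2n1)S(=O)(=O)c1ccccc1` gives 2400 nM in a functional assay on KB cells (Homo sapiens) for antiproliferative activity, read by MTT assay, with a stated time of 72 h; on this read-out higher numbers stand for weaker inhibition and lower numbers for stronger inhibition; it stands second highest of the three numbers, nearest compound 2 `CN(C(=O)c1ccc(Br)cc1)c1ccc2[nH]c(-c3n[nH]c4ccccc34)cc2n1`, which gives 1780 nM, and furthest from compound 1 `CC(=O)N(C)c1ccc2[nH]c(-c3n[nH]c4ccccc34)cc2n1`, which gives 10300 nM. The new compound 4 `COc1ccc(S(=O)(=O)N(C)c2ccc3[nH]c(-c4n[nH]c5ccccc45)cc3n2)c(OC)c1` differs from compound 3 by 2,4-dimethoxyphenyl in place of phenyl on a sulfonyl sulfur. Within the data shown here, no measured step changes a substituent on the sulfonyl aryl ring; the steps that exist concern the group on the ring nitrogen. There, a 5.8-fold lower number from compound 1 to compound 2 (0.76 log units; beyond the scatter) and a 4.3-fold lower number from compound 1 to compound 3 (0.63 log units; beyond the scatter), while a 1.3-fold higher number from compound 2 to compound 3 (0.13 log units; within the scatter). These show that a larger aryl group on this nitrogen is tolerated, but say nothing about methoxy groups on that aryl ring. A step within the scatter, in either direction, is therefore expected, with only a slight lean toward a lower number, as a 1.5-fold lower number from compound 3 to compound 4 (0.18 log units; within the scatter). Compound 4 is estimated at 1600 nM, with a range from 500 nM to 5000 nM.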

Compound 4, half-maximal inhibitory concentration: 10200 nM
The estimate for compound 4 lay 6.4-fold (0.80 log units) below the measured number; the measured number lies above the stated range.
By their numbers in this assay, from the lowest: compounds 2 and 3 (each within the scatter of the next); then compounds 4 and 1 (each within the scatter of the next).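

In this assay, 2,4-dimethoxyphenyl in place of phenyl on a sulfonyl sulfur gives a 4.3-fold higher number from compound 3 to compound 4 (0.63 log units; beyond the scatter), so the aryl ring on the sulfonyl group is not indifferent to substitution, and this change moves the number toward weaker inhibition. This step is the only one shown that alters that ring rather than the group on the ring nitrogen, and it shows that tolerance of a larger aryl group on that nitrogen does not extend to this dimethoxy pattern. Nothing given here accounts for the step.

The compounds shown leave open whether a single methoxy group would produce a similar step, and which of the two positions in the 2,4-dimethoxyphenyl group matters more. They also leave open how the sulfonyl aryl ring would respond to an amine or a carboxylic acid in place of the methoxy groups.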